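Changing the Side Chain on the Chain Carbon of Compound 1

The source may hold more compounds than are shown below. What is called first, only, known or untested is meant among the compounds shown, and "the series" means these compounds.

Compound 1 `CC(C)[C@H](NC(=O)CN(c1nc(Cl)nc2[nH]cnc12)C1CC1)C(=O)OCc1ccccc1` was tested in a functional assay on the whole organism (Tail, strain ICR) with Mus musculus as the target, in the tail flick test, with a stated time of 150 min, at a dose of 25 umol/kg by the oral route (a higher number here means a stronger effect of the compound at the dose given, a lower number a weaker effect), where compound 1 gives 17.9%. Compound 2 `O=C(CN(c1nc(Cl)nc2[nH]cnc12)C1CC1)N[C@@H](CO)C(=O)O` gives 18.8% and compound 3 `CC(C)[C@H](NC(=O)CN(c1nc(Cl)nc2[nH]cnc12)C1CC1)C(=O)O` gives 7.86%, so compound 1 sits in the middle of the three numbers, with both gaps within the usual scatter. Compound 4 `NC(=O)CC[C@H](NC(=O)CN(c1nc(Cl)nc2[nH]cnc12)C1CC1)C(=O)OCc1ccccc1` differs from compound 1 by 2-carbamoylethyl in place of isopropyl on a saturated chain carbon bound to an amide-type nitrogen and a carbonyl carbon. Among the compounds with values here, two measured steps bear on this. Replacing benzyl by hydrogen gave a number 10 percentage points lower from compound 1 to compound 3 (within the scatter). At the same chain carbon as the present change, a number 10.9 percentage points lower from compound 2 to compound 3 (beyond the scatter), meaning that the swap away from isopropyl toward a group carrying a hydrogen-bond donor and acceptor went the other way. A small rise or no change beyond the scatter is therefore expected. Compound 4 is estimated to give 21%, between 10% and 33%, an expected step of a number 3.1 percentage points higher from compound 1 to compound 4 (within the scatter).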

Compound 4, a percentage reported as activity, at one dose (the size of the read-out at that dose, not a potency): 31.1%
Beside the measured number, compound 4's estimate is 10.1 percentage points below it, within the range that was stated.
By their numbers in this assay, from the lowest: compounds 3, 1 and 2 (each within the scatter of the next, the first and the last beyond it); then compound 4.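

With the benzyl kept, 2-carbamoylethyl in place of isopropyl on the saturated chain carbon gives a number 13.2 percentage points higher from compound 1 to compound 4 (beyond the scatter) in this assay. Leaving isopropyl at this carbon now raises the number in a benzyl compound too, whereas the earlier step here involved only compounds without benzyl. Nothing measured here gives the reason for this rise. Still open, going by these compounds, is whether the rise follows the terminal amide or the chain itself, which a plain propyl chain, a carboxylic acid or an amine at that chain end could separate. Also open, on these data alone, is whether 2-carbamoylethyl has the same effect with hydrogen in place of benzyl.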